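Silyl-to-benzyl swap on the shared core, cytotoxicity notes

A few compounds are considered here, and "the series" means these few. Any claim that something is new, unique, unknown or untested is made for them only; others in the source may bear on it.

Compound 3 `Cc1cn([C@@H]2O[C@H](CO[Si](C(C)C)(C(C)C)C(C)C)[C@@]3(OS(=O)(=O)C=C3NC(=O)NC(=O)c3ccccc3)[C@H]2O[Si](C)(C)C(C)(C)C)c(=O)n(C)c1=O` stands only at a limit in an ADME assay on HEL cells (Homo sapiens) for cytotoxicity, with a stated time of 3 days; a higher number here means that more compound is tolerated, a lower number that less compound is tolerated: compound 3 gives > 100000 nM, which is a limit of the assay and not a number. Compound 1 `Cc1cn([C@@H]2O[C@H](CO)[C@@]3(OS(=O)(=O)C=C3NC(=O)NC(=O)c3ccccc3)[C@H]2O[Si](C)(C)C(C)(C)C)c(=O)n(C)c1=O` gives 16000 nM. Compound 2 `Cc1cn([C@@H]2O[C@H](CO)[C@@]3(OS(=O)(=O)C=C3NC(=O)NC(=O)c3ccccc3)[C@H]2O)c(=O)n(C)c1=O` gives > 50000 nM, again a limit. Compound 4 `Cc1cn([C@@H]2O[C@H](COCc3ccccc3)[C@@]3(OS(=O)(=O)C=C3NC(=O)NC(=O)c3ccccc3)[C@H]2O[Si](C)(C)C(C)(C)C)c(=O)n(C)c1=O` carries a group of 7 heavy atoms (7 carbon; one six-membered aromatic ring of carbon only) in place of a group of 10 heavy atoms (9 carbon, 1 silicon; no ring), on an oxygen on a saturated carbon. Going by the values given here, the measured steps that bear on it, both on an oxygen on a saturated carbon, are an at least 6.2-fold higher number from compound 1 to compound 3 (0.79 log units; beyond the scatter) and an at least 3.1-fold higher number from compound 1 to compound 2 (0.49 log units; beyond the scatter); both end at limits, so their full size is unknown, and no measured compound carries a benzyl group. The step of an at least 2.0-fold lower number from compound 3 to compound 4 (0.30 log units; that floor lies within the scatter) is therefore expected to be a downward one of uncertain size. Compound 4 is estimated at 50000 nM, with a range from 15000 nM to 150000 nM.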

Compound 4, half-maximal cytotoxic concentration: > 50000 nM
Compound 4: only a limit was reported; the forecaster's own chance of this, stated with the estimate: 40%; the middle value sits exactly at the limit.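

In this assay, benzyl in place of hydrogen on this oxygen gives an at least 3.1-fold higher number from compound 1 to compound 4 (0.49 log units; beyond the scatter), so an ether with an aromatic ring here also leaves the free hydroxyl of compound 1 behind, as the silyl group of compound 3 does. Compound 3 and compound 4 both stand at limits, and the step between them cannot be read. The benzyl change therefore shows no sign of a lower tolerated concentration than compound 1, but it cannot be ranked against the silyl group. From the compounds shown here alone, how far the true values of compound 3 and compound 4 lie beyond their limits stays open. So does how a methyl ether or an amine at this place would read in this assay.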